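This account rests on a few compounds, and the source may have more. Where it says the series, first, only, none or still open, it means among the compounds named here.

Measured so far:
compound 1 `COc1ncc(-c2ccc3nc(NC(C)=O)nn3c2)cc1NS(=O)(=O)c1ccc(F)cc1`, 1820 nM
compound 2 `CCOCCNc1nc2ccc(-c3cnc(OC)c(NS(=O)(=O)c4ccc(F)cc4)c3)cn2n1`, 8150 nM

Compound 2 stands at the higher of the two numbers: in a functional assay on U-87MG ATCC cells (Homo sapiens) for antiproliferative activity, read by MTT assay, with a stated time of 48 h (on this read-out higher numbers stand for weaker inhibition and lower numbers for stronger inhibition), compound 2 gives 8150 nM, while compound 1 gives 1820 nM. Within the data shown here, the one step in hand is a 4.5-fold higher number from compound 1 to compound 2 (0.65 log units; beyond the scatter), an exchange on a nitrogen on an aromatic ring.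

Compound 3 `CCOC(=O)CNc1nc2ccc(-c3cnc(OC)c(NS(=O)(=O)c4ccc(F)cc4)c3)cn2n1` differs from compound 2 in one place: ethoxycarbonyl in place of ethoxymethyl on a saturated chain carbon bound to a nitrogen on an aromatic ring. This change touches the same chain as the measured step but not the same pair of groups, so that step bears on it only loosely; it shows that alterations on this nitrogen can shift the number modestly, without telling the direction here. The step from compound 2 to compound 3 is therefore expected to be small and uncertain, a 1.4-fold lower number from compound 2 to compound 3 (0.13 log units; within the scatter). Compound 3 is expected to give about 6000 nM in this assay, within 2000 nM to 18000 nM.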

Compound 3, half-maximal inhibitory concentration: 7940 nM
Compound 3: the middle estimate sits 1.3-fold (0.12 log units) below what was measured, within the range that was stated.
By their numbers in this assay, from the lowest: compound 1; then compounds 3 and 2 (each within the scatter of the next).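

In this assay, ethoxycarbonyl in place of ethoxymethyl on the saturated chain carbon leaves the read-out within the scatter, with a 1.0-fold lower number from compound 2 to compound 3 (0.01 log units; within the scatter), so this exchange on the chain does not separate the two compounds. The (ethoxycarbonyl)methyl group also stands apart from acetyl on the nitrogen, with a 4.4-fold higher number from compound 1 to compound 3 (0.64 log units; beyond the scatter), a step beyond the scatter, so compound 1 now holds the lowest number of the three, and a second chain on this nitrogen has given a higher number than acetyl. Nothing available explains why these two chains read alike or why both differ from acetyl.

The compounds shown leave open how a free carboxylic acid or an amine at the end of this chain would read. They also leave open whether a longer acyl group, such as propanoyl, would stay close to acetyl.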